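Indane propargylamines: para-fluoro added to the meta-fluoro benzylthio

A few compounds are considered here, and "the series" means these few. Any claim that something is new, unique, unknown or untested is made for them only; others in the source may bear on it.

Measured so far, in an ADME assay on isolated protein for inhibition of Amine oxidase [flavin-containing] B (Homo sapiens); a lower number here means a stronger inhibitor, a higher number a weaker inhibitor:
compound 1 `C#CCNC1CCc2c(SCc3cccc(F)c3)cccc21` gives 11600 nM
compound 2 `C#CCNC1CCc2c(SCc3ccc(Br)cc3)cccc21` gives 488 nM
compound 3 `C#CCNC1CCc2c(SCc3cccc(Br)c3)cccc21` reaches only the limit of the assay, > 100000 nM

Compound 1 stands highest of the two numbers in this assay; its nearest neighbour is compound 2, reached by a 24-fold lower number from compound 1 to compound 2 (1.38 log units; beyond the scatter). Compound 3 sits at the limit of > 100000 nM in this assay, at which 1 of the 3 values shown sits, and gives no number.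

Compound 4 `C#CCNC1CCc2c(SCc3ccc(F)c(F)c3)cccc21` differs from compound 1 by fluoro in place of hydrogen on an aromatic carbon. The measured steps all touch the same benzylthio ring. Substitution para to the large group pays off: a 24-fold lower number from compound 1 to compound 2 (1.38 log units; beyond the scatter). Substitution meta to it costs: an at least 200-fold higher number from compound 2 to compound 3 (2.31 log units; beyond the scatter) and an at least 8.6-fold higher number from compound 1 to compound 3 (0.93 log units; beyond the scatter). Compound 4 keeps the meta fluoro of compound 1 and adds a para fluoro, so a lower number than compound 1 is expected in this assay, though a step smaller than that from compound 1 to compound 2, as fluoro is a smaller group than bromo. The expected step is a 3.9-fold lower number from compound 1 to compound 4 (0.59 log units; beyond the scatter). Compound 4 is therefore estimated at 3000 nM, within 800 nM to 12000 nM.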

Compound 4, half-maximal inhibitory concentration: 2630 nM
Compound 4: the middle estimate sits 1.1-fold (0.06 log units) above what was measured; measured number inside the range.
By their numbers in this assay, from the lowest: compound 2; then compound 4; then compound 1. At a limit, above all of these: compound 3.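

In this assay the added fluoro, ortho to a fluoro group and para to a large group, gives a 4.4-fold lower number from compound 1 to compound 4 (0.64 log units; beyond the scatter) as a change made in one place only. Compound 1 keeps its fluoro in compound 4, so this position alone accounts for the gain, which the earlier steps could not show: the step to compound 2 changed both the halogen and its place on the ring. Even a single heavy atom at this position is enough to move the number beyond the scatter, and the existing fluoro on the ring does not prevent this.

Still open, from the compounds shown here alone, is how a chloro, a methoxy or a trifluoromethyl group at this position would compare, and what a fluoro here would do with no second fluoro on the ring. Nothing measured here gives a cause for this step.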